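Dropping the aromatic methyl in the series

A few compounds are considered here, and "the series" means these few. Any claim that something is new, unique, unknown or untested is made for them only; others in the source may bear on it.

In a physicochemical assay for lipophilicity (a lower number here means a more polar compound, a higher number a more lipophilic compound), compound 2 (`CNC(=O)c1cc(C(=O)N[C@H]2CC[C@H](O)CC2)c([C@@H](C)c2cccc(C)c2)o1`) gives 3.3, the lowest of the three numbers in hand. Compound 1 (`CNC(=O)c1cc(C(=O)N[C@H]2CC[C@H](O)CC2)c([C@@H](C)c2cccc(F)c2)o1`) gives 4.1. Compound 3 (`CNC(=O)c1cc(C(=O)N[C@H]2CC[C@H](OC)CC2)n([C@@H](C)c2ccccc2)n1`) gives 4.2, and both of these stand beyond the scatter from compound 2.

The next compound is compound 4 (`CNC(=O)c1cc(C(=O)N[C@H]2CC[C@H](O)CC2)c([C@@H](C)c2ccccc2)o1`), with hydrogen in place of methyl on an aromatic carbon.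

Among the measured compounds shown here, only one measured step bears on this. It is a number 0.80 log units lower from compound 1 to compound 2 (beyond the scatter), with methyl in place of fluoro on the same aromatic carbon. That step shows that a change at this place can move the number by a modest amount, but it does not involve hydrogen, so it gives no direction for compound 4. For the measured compounds named here, compound 3 differs from compound 2 in more than one place and offers no step here.

Going by the values given here, with no direct precedent, no shift beyond the scatter is expected, and a number 0.10 log units higher from compound 2 to compound 4 (within the scatter) is the expected step. The range stays wide and reaches upward, since compound 1 at 4.1 marks how far this place can carry the number. The estimated value for compound 4 is 3.4, expected within 2.9 to 4.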

Compound 4, distribution coefficient: 2.8
For compound 4 the middle estimate is 0.60 log units above the measured one; the measured number lies below the stated range.
By their numbers in this assay, from the lowest: compound 4; then compound 2; then compounds 1 and 3 (each within the scatter of the next).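

In this assay, this aromatic carbon now has three measured occupants on an otherwise unchanged compound, and hydrogen gives the lowest number of the three: a number 0.50 log units lower from compound 2 to compound 4 (beyond the scatter), while the wider comparison reads a number 1.30 log units lower from compound 1 to compound 4 (beyond the scatter). The earlier step gave only the gap between methyl and fluoro, whereas hydrogen now provides a reference point, and both substituted compounds stand on the same side of it, with the fluoro compound furthest away. No measurement at hand accounts for this order, so the steps remain a description of the numbers and offer no explanation.

Among the compounds shown here, whether the same order holds on another core remains open, since compound 3, the only compound with a different core, differs from the others in more than one place. Also open, from the compounds shown here alone, is where a chloro, methoxy, trifluoromethyl or aminomethyl group on this aromatic carbon would fall relative to hydrogen, methyl and fluoro, and so whether the order seen across these three groups extends to any further group.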